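The source may hold more compounds than are shown below. What is called first, only, known or untested is meant among the compounds shown, and "the series" means these compounds.

Measured so far in a functional assay on MDA-MB-231 cells (Homo sapiens) for antiproliferative activity, read by MTT assay, with a stated time of 24 h; on this read-out lower numbers stand for stronger inhibition and higher numbers for weaker inhibition:
compound 1 `O=C(c1cc(Cl)ccn1)N1CCN(c2nccc(Oc3cc(Cl)cc(Cl)c3)n2)CC1`: 16700 nM
compound 2 `COc1ccccc1S(=O)(=O)N1CCN(c2nccc(Oc3cc(Cl)cc(Cl)c3)n2)CC1`: 16800 nM

Compound 1 and compound 2 lie within the scatter of each other; the two values show no difference. Compound 3 `O=C(Nc1ccc2ccccc2c1)N1CCN(c2nccc(Oc3cc(Cl)cc(Cl)c3)n2)CC1` is not yet measured. It differs from compound 1 in one place: (naphthalen-2-yl)amino in place of 4-chloropyridin-2-yl on a carbonyl carbon. Among the measured compounds shown here, no step between measured compounds covers this kind of change, so only the shared core and the two values give a footing. No step beyond the scatter is expected in this assay; the estimated step is a 1.4-fold lower number from compound 1 to compound 3 (0.14 log units; within the scatter). For compound 3 the expected value in this assay is 12000 nM, with a range of 4000 nM to 40000 nM.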

Compound 3, half-maximal inhibitory concentration: 46800 nM
The estimate for compound 3 lay 3.9-fold (0.59 log units) below the measured number, and the stated range ends below it.
By their numbers in this assay, from the lowest: compounds 1 and 2 (each within the scatter of the next); then compound 3.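

In this assay the group on the carbonyl carbon of the shared core matters: (naphthalen-2-yl)amino in place of 4-chloropyridin-2-yl gives a 2.8-fold higher number from compound 1 to compound 3 (0.45 log units; beyond the scatter) and so moves the number beyond the scatter, though the step is modest. The change brings in a second aromatic ring and a hydrogen-bond donor together, and this one step does not separate them. Nothing measured bears on the reason for the step.

Open, as far as these compounds go, is how phenylamino or 4-chloropyridin-2-ylamino would stand on the same carbonyl carbon, which would separate the ring count from the donor.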